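The source may hold more compounds than are shown below. What is called first, only, known or untested is meant among the compounds shown, and "the series" means these compounds.

Series notes. Compound 1 `CCOc1cccc(-c2ccc(C(=O)N(Cc3cccc(OCCCCCC(=O)O)c3)C(C)C)cc2)c1`, compound 2 `CC(C)N(Cc1cccc(OCCCCCC(=O)O)c1)C(=O)c1ccc(-c2ccc3c(c2)OCCO3)cc1` and compound 3 `CCOC(=O)CCCCCOc1cccc(CN(C(=O)c2ccc(-c3cccc(OCC)c3)cc2)C(C)C)c1` have been run in an ADME assay on HepG2 cells (Homo sapiens) for cytotoxicity, read by CellTiter-Glo and resazurin assay, with a stated time of 72 h; a higher number here means that more compound is needed for the effect, a lower number that less compound is needed. In this assay compound 1 gives only a limit, > 20800 nM. Compound 2 likewise gives only a limit, > 21900 nM. Compound 3 also gives only a limit, > 22300 nM. The change from compound 1 to compound 2 is 2,3-dihydro-1,4-benzodioxin-6-yl in place of 3-ethoxyphenyl on an aromatic carbon; its step that the two limits leave unreadable from compound 1 to compound 2 cannot be sized because the limit of > 20800 nM in this assay, at which 1 of the 3 values shown sits, and the limit of > 21900 nM in this assay, at which 1 of the 3 values shown sits, cap both values. The cores of compound 1 and compound 3 differ by ethyl in place of hydrogen on an oxygen next to a carbonyl group, and a step that the two limits leave unreadable from compound 1 to compound 3 is equally unreadable. Compound 4 `CCOC(=O)CCCCCOc1cccc(CN(C(=O)c2ccc(-c3ccc4c(c3)OCCO4)cc2)C(C)C)c1`, not yet measured, carries the same change on the core of compound 3: 2,3-dihydro-1,4-benzodioxin-6-yl in place of 3-ethoxyphenyl on an aromatic carbon. In this assay the step from compound 3 to compound 4 is expected to be an at least 1.0-fold lower number from compound 3 to compound 4 (0.00 log units; that floor lies within the scatter), because the limit of > 20800 nM in this assay, at which 1 of the 3 values shown sits, and the limit of > 21900 nM in this assay, at which 1 of the 3 values shown sits, show the same change leaving both sides at the limit. Compound 4 is therefore expected at 22000 nM, between 12000 nM and 45000 nM, most probably as a limit again.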

Compound 4, half-maximal effective concentration: > 24400 nM
Compound 4 was reported as a limit; the forecaster's own chance of this, stated with the estimate: 85%; at least 1.1-fold (0.04 log units) between middle value and limit.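

Compound 4 gives only a limit in this assay, as do compound 2 and compound 3, so the steps to compound 4 from compound 2 and compound 3 cannot be read. The compounds shown leave open what concentration of any of them gives the half-maximal effect.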